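A few compounds are considered here, and "the series" means these few. Any claim that something is new, unique, unknown or untested is made for them only; others in the source may bear on it.

Measured so far:
- Compound 1 `COc1ccc(Sc2cn(-c3ccc4c(c3)B(O)OC4)c3ccccc23)cc1` gives > 10 ug/mL in an ADME assay on L929 cells (Mus musculus) for cytotoxicity, read by resazurin assay, with a stated time of 72 h (a higher number here means a weaker inhibitor, a lower number a stronger inhibitor), a limit of the assay and not a number.
- Compound 2 `COc1ccc([S+]([O-])c2cn(-c3ccc4c(c3)B(O)OC4)c3ccccc23)cc1` gives > 10 ug/mL in this assay, again a limit.
- Compound 3 `O=C(c1ccc(F)cc1)c1ccn(-c2ccc3c(c2)B(O)OC3)c1` gives > 10 ug/mL in this assay, also a limit.

Compound 3 therefore stands at the ceiling of the numbers shown: its value is the limit of > 10 ug/mL in this assay, at which 3 of the 3 values shown sit, so no number separates it from the other two, and nothing can be said about order among compounds 1, 2 and 3 beyond the fact that each sits at that limit.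

The step to compound 4 `CCCC(=O)c1ccn(-c2ccc3c(c2)B(O)OC3)c1` changes only the ketone substituent: propyl in place of 4-fluorophenyl on a carbonyl carbon. For the measured compounds named here, no measured step between any two compounds exists, so there is no record here of what such a change does to the read-out. With every value at the limit, the working expectation for the step in this assay is none beyond the scatter, in neither direction.

For compound 4 the half-maximal inhibitory concentration is estimated at 15 ug/mL, within 7 ug/mL to 40 ug/mL, and the step that the limit leaves unreadable from compound 3 to compound 4 is the expectation that compound 4 will most likely again be reported as a limit rather than a number.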

Compound 4, half-maximal inhibitory concentration: > 10 ug/mL
Compound 4 ended at the assay's limit (the forecaster's own chance of this, stated with the estimate: 85%); the middle value lies beyond the limit too.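

No step can be read between compound 3 and compound 4 in this assay because both values are limits and not numbers: the limit of > 10 ug/mL in this assay, at which 4 of the 4 values shown sit.

The compounds shown leave open where any of them would give a number in this assay and whether propyl and 4-fluorophenyl on the carbonyl carbon differ at all in this read-out.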